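The source may hold more compounds than are shown below. What is called first, only, known or untested is meant among the compounds shown, and "the series" means these compounds.

In a functional assay on Shh Light II cells (Mus musculus) for inhibition, read by a luciferase reporter (on this read-out lower numbers stand for stronger inhibition and higher numbers for weaker inhibition), compound 1 (`CC(C)c1ccccc1NC(=O)N1CCC(c2nc(-c3ccc4ccccc4n3)no2)CC1`) gives 480 nM and compound 2 (`O=C(NC1CC[S+]([O-])CC1)N1CCC(c2nc(-c3ccc4ccccc4n3)no2)CC1`) gives 850 nM. For the measured compounds named here, compound 2 therefore stands within the usual scatter of the only other number available. Compound 3 (`O=C(OC1CCCCC1)N1CCC(c2nc(-c3ccc4ccccc4n3)no2)CC1`) keeps the shared core and differs from compound 2 at one place: a group of 7 heavy atoms (6 carbon, 1 oxygen; one six-membered non-aromatic ring of carbon only) in place of a group of 8 heavy atoms (5 carbon, 1 nitrogen, 1 oxygen, 1 sulfur; one six-membered non-aromatic ring with 1 hetero atom), on a carbonyl carbon. The entering group is cyclohexyloxy, and it sits on a carbonyl carbon whose other neighbours are an amide-type nitrogen in a ring. Going by the values given here, only one measured step bears on this change, a 1.8-fold higher number from compound 1 to compound 2 (0.25 log units; within the scatter). Among the compounds with values here, that step exchanged a different pair of groups, on an amide-type nitrogen, so it offers only indirect guidance, and no measured step involves cyclohexyloxy. No step beyond the scatter is therefore expected in this assay. The expected change is a 1.4-fold lower number from compound 2 to compound 3 (0.15 log units; within the scatter). For compound 3 the estimated value is 600 nM, with an expected range of 200 nM to 1800 nM.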

Compound 3, half-maximal inhibitory concentration: 580 nM
For compound 3 the middle estimate is 1.0-fold (0.01 log units) above the measured one; measured number inside the range.
By their numbers in this assay, from the lowest: compounds 1, 3 and 2 (each within the scatter of the next).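

In this assay, the carbonyl carbon now carries a group with an oxygen rather than a nitrogen attached: cyclohexyloxy, with 0 hydrogen-bond donors, replaces a group with 1 hydrogen-bond donor, and the result is a 1.5-fold lower number from compound 2 to compound 3 (0.17 log units; within the scatter) and no step beyond the scatter. Set against (2-isopropylphenyl)amino, the same group gives a 1.2-fold higher number from compound 1 to compound 3 (0.08 log units; within the scatter), so neither comparison separates cyclohexyloxy from the group it replaces in this assay. No measurement given here accounts for these small steps. From the compounds shown here alone, it remains open whether an open chain such as n-butoxy, or a cyclohexyloxy bearing a carboxylic acid or an amine, would stay within the scatter on this carbonyl carbon. Also open, going by these compounds, is whether any group there can move the number beyond the scatter at all.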